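Swapping Fluoro for Chloro: What a Single Atom May Do

The compounds below may be only part of what the source reports. "The series", "measured", "known", "first", "only" and "open" are said of these compounds alone.

Of the compounds shown here, two have so far been tested in a functional assay on cells for positive allosteric modulation of G-protein coupled receptor 68 (Homo sapiens), read by a luciferase reporter and cAMP accumulation, with a stated time of 30 min, at pH 6.8 and pH 8.3, in the presence of a further agent that is not named here; a lower number here means a less potent compound, a higher number a more potent compound, by a factor of ten per unit of this negative logarithm. Compound 1 `CCNc1nc(NCc2ccccc2)nc(-c2ccccc2CO)n1` gives 4.63. Compound 2 `Nc1nc(NCc2ccccc2)nc(-c2c(F)cccc2CO)n1` gives 3.69. Of these two numbers, compound 2 stands lowest; its gap to compound 1 is larger than the usual scatter of this assay, but the two compounds differ in more than one place, so that gap cannot be tied to any single change.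

Compound 3 `Nc1nc(NCc2ccccc2)nc(-c2c(Cl)cccc2CO)n1` has not yet been measured. It differs from compound 2 in one place only: chloro in place of fluoro on an aromatic carbon. Among the measured compounds shown here, no measured pair here shows what such a swap does, so the data give no ground for predicting a large step in either direction. One halogen replaces another, and the counts of ring atoms, hydrogen-bond donors, hydrogen-bond acceptors and charge stay the same. The expectation for this assay is therefore a modest shift at most, with the step from compound 2 to compound 3 estimated as a number 0.21 log units higher from compound 2 to compound 3 (within the scatter), not clearly beyond the scatter. Compound 3 is expected to give about 3.9, within a range from 3.3 to 4.6.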

Compound 3, negative logarithm of the antagonist equilibrium constant: 4.43
The estimate for compound 3 lay 0.53 log units below the measured number; measured number inside the range.
By their numbers in this assay, from the lowest: compound 2; then compounds 3 and 1 (each within the scatter of the next).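

Among the compounds shown here, this is the first pair here that differs in one place only, so a change in this assay can be tied to a single atom: chloro in place of fluoro on an aromatic carbon, ortho to a large group and meta to a hydroxymethyl group, gives a number 0.74 log units higher from compound 2 to compound 3 (beyond the scatter) and lies beyond the usual scatter. The read-out at this position therefore depends on which halogen is present, even though the counts of rings, hydrogen-bond donors, hydrogen-bond acceptors and charge stay the same. No measurement shown here explains how this single swap produces the step.

The compounds shown leave open whether the trend extends beyond these two halogens, which a bromo, methyl, methoxy or nitrile group at the same place could test. They also leave open whether chloro and fluoro would differ by a similar amount if the free amine shared by compound 2 and compound 3 were replaced by the ethylamino group of compound 1.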